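Swapping the bicyclic heteroaryl arm on the alkene core

This account rests on a few compounds, and the source may have more. Where it says the series, first, only, none or still open, it means among the compounds named here.

Among the compounds with values here, compound 1 `CC/C(=C(/c1ccc(/C=C/C(=O)O)cc1)c1ccc2nccn2c1)c1ccccc1` is the only member of this set with a measured number: in a functional assay on MCF7 cells (Homo sapiens) for antiproliferative activity, read by CellTiter-Glo, with a stated time of 5 days (on this read-out higher numbers stand for weaker inhibition and lower numbers for stronger inhibition), compound 1 gives 170 nM. Compound 2 `CC/C(=C(/c1ccc(/C=C/C(=O)O)cc1)c1ccc2cncn2c1)c1ccccc1` reaches only a limit of this assay, > 500 nM. Compound 3 `CC/C(=C(/c1ccc(/C=C/C(=O)O)cc1)c1ccc2nnnn2c1)c1ccccc1` likewise stops at a limit, > 500 nM. Both replacements of the bicyclic arm therefore weakened inhibition: an at least 2.9-fold higher number from compound 1 to compound 2 (0.46 log units; beyond the scatter) and an at least 2.9-fold higher number from compound 1 to compound 3 (0.46 log units; beyond the scatter), each resting on (the limit of > 500 nM in this assay, at which 2 of the 3 values shown sit). Compound 4 `CC/C(=C(/c1ccc(/C=C/C(=O)O)cc1)c1ccc2ocnc2c1)c1ccccc1` carries a third variant at the same place, (a group of 9 heavy atoms (7 carbon, 1 nitrogen, 1 oxygen; one five-membered aromatic ring with 2 hetero atoms, one six-membered aromatic ring of carbon only) in place of a group of 9 heavy atoms (7 carbon, 2 nitrogen; one five-membered aromatic ring with 2 hetero atoms, one six-membered aromatic ring with 1 hetero atom), on a double-bonded chain carbon bound to an aromatic carbon and a double-bonded chain carbon). Because an at least 2.9-fold higher number from compound 1 to compound 2 (0.46 log units; beyond the scatter) and an at least 2.9-fold higher number from compound 1 to compound 3 (0.46 log units; beyond the scatter) both went toward weaker inhibition, a similar loss is expected for compound 4, a 2.6-fold higher number from compound 1 to compound 4 (0.42 log units; beyond the scatter). Compound 4 is accordingly estimated at 450 nM in this assay, between 150 nM and 1500 nM.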

Compound 4, half-maximal inhibitory concentration: > 500 nM
Compound 4 ended at the assay's limit; the forecaster's own chance of this, stated with the estimate: 40%; middle value at least 1.1-fold (0.04 log units) from the limit.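

In this assay the 1,3-benzoxazol-5-yl group also falls short of the group it replaces, with an at least 2.9-fold higher number from compound 1 to compound 4 (0.46 log units; beyond the scatter) as a step that rests on a limit of the assay. The loss at this place now extends to a group whose six-membered aromatic ring is carbon only, although the two groups match in heavy atoms, hydrogen-bond donors, hydrogen-bond acceptors and net charge. The steps among compound 2, compound 3 and compound 4 cannot be read: the limit of > 500 nM in this assay, at which 3 of the 4 values shown sit.

Going by these compounds, how far these three lie from one another stays open. Also open, on these data alone, is whether an amine or a methoxy group on the bicyclic arm of compound 1 would keep its inhibition.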